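Carbocyclic series: removing fluoro from compound 2

The compounds below may be only part of what the source reports. "The series", "measured", "known", "first", "only" and "open" are said of these compounds alone.

Measured in a functional assay on PBM cells (Homo sapiens) for cytotoxicity; on this read-out lower numbers stand for stronger inhibition and higher numbers for weaker inhibition:
- compound 1 `CC(=O)OC[C@@H]1C=C[C@H](n2cc(F)c(N)nc2=O)O1` gives > 100000 nM
- compound 2 `Nc1nc(=O)n(C2C=CC(CO)C2)cc1F` gives > 100000 nM

Within the data shown here, both entries are limits of the assay and not numbers, so the series so far amounts to the limit of > 100000 nM in this assay, at which 2 of the 2 values shown sit. Compound 2 therefore stands at a limit, with no exact value.

Compound 3 `Nc1ccn(C2C=CC(CO)C2)c(=O)n1` has hydrogen in place of fluoro on an aromatic carbon, ortho to an amino group (hydrogen in place of fluoro on an aromatic carbon) . Among the measured compounds shown here, no step between measured compounds is available to size this change. From the limit of compound 2 at > 100000 nM, a reading at the same limit remains a likely outcome for compound 3. The estimated step of an at least 1.4-fold lower number from compound 2 to compound 3 (0.15 log units; that floor lies within the scatter) is expected to be modest and toward stronger inhibition in this assay. Compound 3 is estimated at 70000 nM, with an expected range of 15000 nM to 100000 nM.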

Compound 3, half-maximal inhibitory concentration: > 100000 nM
Compound 3: only a limit was reported; the forecaster's own chance of this, stated with the estimate: 55%; at least 1.4-fold (0.15 log units) between middle value and limit.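

In this assay compound 3 gives > 100000 nM, a limit of the assay and not a number. Among these compounds, compound 2 also sits at a limit, so no step from compound 2 to compound 3 can be read. The compounds shown leave open whether exchanging fluoro for hydrogen changes this assay at all.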